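Methyl in place of methoxy: expected maximal response

A few compounds are considered here, and "the series" means these few. Any claim that something is new, unique, unknown or untested is made for them only; others in the source may bear on it.

Measured so far in a functional assay on HEK293 cells for agonist activity at D(4) dopamine receptor (Homo sapiens), read by FLIPR; a higher number here means a larger maximal response, a lower number a smaller maximal response:
- compound 1 `COc1ccccc1C1CCN(CC(=O)Nc2cccc(C)c2)CC1` gives 43%
- compound 2 `O=C(NCN1CCC(c2cccc[n+]2[O-])CC1)c1cnccc1Cl` gives 44%
- compound 3 `O=C(NCN1CCC(c2cccc[n+]2[O-])CC1)c1ccc2ccccc2c1` gives 67%

Compound 1 has the lowest of the three numbers in this assay. Compound 2 lies within the scatter of it, so the two are not told apart. Compound 3 lies beyond the scatter above compound 1.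

Compound 4 `Cc1cccc(NC(=O)CN2CCC(c3ccccc3C)CC2)c1` differs from compound 1 by methyl in place of methoxy on an aromatic carbon. Going by the values given here, no measured pair shows this change, so nothing in the numbers points to a direction. The step from compound 1 is expected to be small, a number 1 percentage points lower from compound 1 to compound 4 (within the scatter), within the scatter. For compound 4 the estimate in this assay is 42%, between 25% and 60%.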

Compound 4, largest response reached (reported as efficacy), in percent of the reference or control that the assay uses: 43%
Beside the measured number, compound 4's estimate is 1 percentage points below it, and the stated range covers the measured number.
By their numbers in this assay, from the lowest: compounds 1, 4 and 2 (each within the scatter of the next); then compound 3.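

Going by these compounds alone, on the core of compound 1, this is the first pair read at this position: in this assay, going from 2-methoxyphenyl to 2-methylphenyl gives no change at the digits printed from compound 1 to compound 4 (within the scatter). The position therefore tolerates the loss of the methoxy oxygen, with its one hydrogen-bond acceptor, without a shift in maximal response that can be told from scatter. Nothing available explains this outcome. Open, as far as these compounds go, is whether an amine, a carboxylic acid or a longer chain on this aromatic carbon would move the response, and whether the same swap reads alike on another core.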